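The source may report more compounds than this note shows. Statements on the series, on what has been measured and on what is new or still open speak of the compounds shown alone.

Working notes on the series. The three measured compounds share one core: compound 1 `CCCCCCCCc1ccc(OCC(=O)Cn2nnc(-c3ccc(C(=O)OC)cc3)n2)cc1`, compound 2 `CCCCCCCCc1ccc(OC(C)C(=O)Cn2nnc(-c3ccc(Cl)cc3)n2)cc1` and compound 3 `CCCCCCCCc1ccc(OC(C)C(=O)Cn2nnc(-c3ccc(C(=O)OC)cc3)n2)cc1`. In an ADME assay on S9 fraction from liver (Rattus norvegicus) for metabolic stability, read by LC-MS, using NADPH, with a stated time of 30 min (a lower number here means that less of the compound is left, a higher number that more of the compound is left), compound 1 gives 64%, compound 2 gives 72% and compound 3 gives 62%. Compound 3 holds the lowest of the three numbers, but the gaps to it are small: a number 2 percentage points lower from compound 1 to compound 3 (within the scatter) and a number 10 percentage points lower from compound 2 to compound 3 (within the scatter), so the three compounds cannot be told apart on these numbers.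

The next compound, compound 4 `COC(=O)c1ccc(-c2nnn(CC(=O)C(C)Oc3ccc(-c4ccccc4)cc3)n2)cc1`, differs from compound 3 in one place: phenyl in place of octyl on an aromatic carbon. Neither measured step touches this position; the step from compound 1 to compound 3 concerns a methyl on the saturated chain and the step from compound 2 to compound 3 concerns the group on the other aromatic ring. For the measured compounds named here, there is therefore no measured step that bears on the exchange of octyl for phenyl, and the expectation can only start from compound 3 itself, with a wide range. In this assay compound 4 is expected to give 62%, between 35% and 85%. The expected step is no change at the digits printed from compound 3 to compound 4 (within the scatter), estimated as no change beyond the scatter, for want of any step on this position.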

Compound 4, percent of the compound remaining: 21%
Estimate against measurement, compound 4: 41 percentage points above, outside the stated range (below it).
By their numbers in this assay, from the lowest: compound 4; then compounds 3, 1 and 2 (each within the scatter of the next).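

In this assay, for the compounds shown here, phenyl in place of octyl on an aromatic carbon, para to a large group, gives a number 41 percentage points lower from compound 3 to compound 4 (beyond the scatter) and is the first step that is large, whereas the earlier steps on the saturated chain and on the other aromatic ring stayed within the scatter. Going by these compounds alone, this position therefore matters to the read-out in a way the earlier compounds could not show, with a chain without a ring leaving and a six-membered aromatic ring of carbon only entering. Nothing available bears on why the number moves at this position.

From the compounds shown here alone, it remains open whether the step follows from the ring entering or from the octyl chain leaving, which a butyl chain or a cyclohexyl group at this place would help to separate. Going by these compounds, it is also open whether the same exchange gives a step of similar size on the cores of compound 1 and compound 2.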